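The compounds below may be only part of what the source reports. "The series", "measured", "known", "first", "only" and "open" are said of these compounds alone.

The measurement followed here is a physicochemical assay for lipophilicity, using the shake flask method, in phosphate buffer, measured as octanol-water partition, with a stated time of 24 h, at pH 7.4, tested at 100 uM (a higher number here means a more lipophilic compound, a lower number a more polar compound), and the starting point is compound 2 `Cc1cccc(C)c1-c1cccc(COc2ccc(S(=O)(=O)CC(=O)O)cc2)c1` which gives 2.49 on this scale. Of the compounds with a number, compound 2 stands lowest, while compound 1 `Cc1cccc(C)c1-c1cccc(COc2ccc(SCC(=O)O)cc2)c1` gives 3.82 in the same measurement, a clearly higher number. Among the measured compounds shown here, that gap is the only measured step, with a number 1.33 log units lower from compound 1 to compound 2 (beyond the scatter) when (carboxymethyl)sulfonyl takes the place of (carboxymethyl)sulfanyl on an aromatic carbon. Compound 3 `COc1cc(C)c(-c2cccc(COc3ccc4c(c3)SCC4CC(=O)O)c2)c(C)c1` has a different core and offers no guide, since the entry for compound 3 reads "not determined" (no result reported) in this assay and gives no number.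

The new step leads to compound 4 `CCOc1cc(C)c(-c2cccc(COc3ccc(S(=O)(=O)CC(=O)O)cc3)c2)c(C)c1` and is described as ethoxy in place of hydrogen on an aromatic carbon with ethoxy in place of hydrogen on an aromatic carbon, para to a large group and meta to two methyl groups. For the measured compounds named here, the one measured step changes another part of the molecule, so it sets no direct size for this one. What enters adds heavy atoms with no hydrogen-bond donor and no net charge, so a modest rise is expected, much smaller than the measured step. The estimated change is a number 0.41 log units higher from compound 2 to compound 4 (beyond the scatter) and it remains an expectation. For compound 4 the estimate is 2.9 with an expected range of 2.4 to 3.4 as the likely span.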

Compound 4, distribution coefficient: 2.86
The estimate for compound 4 lay 0.04 log units above the measured number, within the range that was stated.
By their numbers in this assay, from the lowest: compound 2; then compound 4; then compound 1.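

In this assay, among the compounds shown here, this is the first measured change at this position, on the ring that carries two methyl groups, and it gives a number 0.37 log units higher from compound 2 to compound 4 (beyond the scatter). For the compounds shown here, the only earlier step, a number 1.33 log units lower from compound 1 to compound 2 (beyond the scatter), came from replacing (carboxymethyl)sulfanyl with (carboxymethyl)sulfonyl in another part of the molecule, so the new result adds a separate piece of information: swapping hydrogen for ethoxy at this position also moves the number beyond the scatter, although this step is modest and the earlier one large. The data shown contain no separate measurement that explains why ethoxy has this effect here.

On these data alone, with a single substituent tested at this position, these compounds do not establish a trend, and the effect of a propoxy chain, a hydroxy group or an amine in the same place remains open. As far as these compounds go, it is also open whether adding ethoxy to compound 1, which carries (carboxymethyl)sulfanyl, would give a step of similar size to the one seen with the (carboxymethyl)sulfonyl group.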